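Aryl amide change from compound 3 to compound 4

The source may hold more compounds than are shown below. What is called first, only, known or untested is meant among the compounds shown, and "the series" means these compounds.

In a functional assay on A549 cells (Homo sapiens) for antiproliferative activity, read by sulforhodamine B assay, with a stated time of 3 days (on this read-out higher numbers stand for weaker inhibition of growth and lower numbers for stronger inhibition of growth), compound 1 `O=C(Nc1ccccn1)c1cccc(Nc2ncc(F)c(Nc3ccc(F)cc3)n2)c1` gives 15300 nM, and compound 2 `O=C(Nc1cccc(Nc2ncc(F)c(Nc3ccc(F)cc3)n2)c1)c1cccc([N+](=O)[O-])c1` gives 7250 nM. Compound 3 `CN(C)c1ccc(C(=O)Nc2cccc(Nc3ncc(F)c(Nc4ccc(F)cc4)n3)c2)cc1` reads > 10000 nM, which is a limit and not a number. Compound 4 `O=C(Nc1cccc(Nc2ncc(F)c(Nc3ccc(F)cc3)n2)c1)c1ccncc1` differs from compound 3 by pyridin-4-yl in place of 4-(dimethylamino)phenyl on a carbonyl carbon, on a carbonyl carbon. Among the compounds with values here, the one measured step at this place is an at least 1.3-fold higher number from compound 2 to compound 3 (0.13 log units; that floor lies within the scatter). That step rests on a limit and stays within the scatter, so it gives no size for a change of this group. Growth inhibition is therefore expected to remain weak, near compound 2 at 7250 nM. Only a small shift is expected, estimated as a number no higher from compound 3 to compound 4 (the limit leaves the size open). For compound 4 the estimate is 10000 nM, with an expected range of 4000 nM to 25000 nM.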

Compound 4, concentration for 50% growth inhibition: 1650 nM
The estimate for compound 4 lay 6.1-fold (0.78 log units) above the measured number, and the stated range ends above it.
By their numbers in this assay, from the lowest: compound 4; then compound 2; then compound 1.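

In this assay, within the data shown here, pyridin-4-yl on the carbonyl carbon gives a 4.4-fold lower number from compound 2 to compound 4 (0.64 log units; beyond the scatter), the first step at this place with a measured size beyond the scatter. Against 4-(dimethylamino)phenyl the change reads an at least 6.0-fold lower number from compound 3 to compound 4 (0.78 log units; beyond the scatter), and that size is only a floor, as compound 3 carries a limit: the limit of > 10000 nM in this assay, at which 1 of the 4 values shown sits. Taking ((pyridin-4-yl)carbonyl)amino in place of (pyridin-2-yl)carbamoyl gives a 9.3-fold lower number from compound 1 to compound 4 (0.97 log units; beyond the scatter).

Open, on these data alone, is how pyridin-3-yl or unsubstituted phenyl would read on this carbonyl carbon. Also open, as far as these compounds go, is whether an aminomethyl group on the pyridine ring would keep compound 4's level of growth inhibition.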